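A few compounds are considered here, and "the series" means these few. Any claim that something is new, unique, unknown or untested is made for them only; others in the source may bear on it.

Measured in an ADME assay on HEK293 cells (Homo sapiens) for cytotoxicity, read by MTT assay, with a stated time of 72 h; on this read-out higher numbers stand for weaker inhibition and lower numbers for stronger inhibition:
- compound 1 `COc1ccc(C2=C(c3cc(OC)c(OC)c(OC)c3)C(=O)C(OC(C)=O)C2)cc1OC(C)C`: > 100 ug/mL (a limit)
- compound 2 `COc1ccc(OC)c(C2=C(c3cc(OC)c(OC)c(OC)c3)C(=O)CC2O[SiH2]C(C)(C)C)c1`: 9.5 ug/mL
- compound 3 `COc1ccc(C2=C(c3cc(OC)c(OC)c(OC)c3)C(=O)C(O)C2)cc1NC(=O)c1ccccc1`: > 100 ug/mL (a limit)

Compound 1 gives no number, only a limit of the assay, and it stands at the limit of > 100 ug/mL in this assay, at which 2 of the 3 values shown sit. Compound 2 is the only one of the three with a true number, at 9.5 ug/mL.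

Next in line is compound 4 `COc1ccc(C2=C(c3cc(OC)c(OC)c(OC)c3)C(=O)C(OC(C)=O)C2)cc1F`, which has fluoro in place of isopropoxy on an aromatic carbon, ortho to a methoxy group and meta to a large group: fluoro in place of isopropoxy on an aromatic carbon. Going by the values given here, no measured pair isolates this change. The estimated step of a number no higher from compound 1 to compound 4 (the limit leaves the size open) is expected to stay within the scatter, with any movement more likely toward stronger inhibition. That expectation leans on compound 3, which carries another group on that aromatic carbon and gives > 100 ug/mL, again a limit. In this assay, compound 4 is more likely than not to be reported only as a limit. For compound 4 the expected value is 100 ug/mL, with an estimated range of 20 ug/mL to 200 ug/mL.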

Compound 4, half-maximal inhibitory concentration: 59 ug/mL
The estimate for compound 4 lay 1.7-fold (0.23 log units) above the measured number; low and high end bracket the measured number.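

In this assay compound 4 gives 59 ug/mL as a true number, so with fluoro in place of isopropoxy on this aromatic carbon, ortho to a methoxy group, the series gives a reading rather than a limit. The change reads as an at least 1.6-fold lower number from compound 1 to compound 4 (0.22 log units; that floor lies within the scatter) and only that floor can be stated. Compound 1 gives > 100 ug/mL as its reading, which is a limit and not a number.

From the compounds shown here alone, whether the true step from the isopropoxy group to fluoro reaches beyond the scatter stays open, as does how an amine, a carboxylic acid or a chloro group on this aromatic carbon would read against compound 4. The limit leaves few true numbers for such comparisons: the limit of > 100 ug/mL in this assay, at which 2 of the 4 values shown sit.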